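The compounds below may be only part of what the source reports. "The series", "measured", "known", "first", "only" and "open" are said of these compounds alone.

Three compounds sharing one core were tested in an ADME assay on BHK cells (Mesocricetus auratus) for cytotoxicity, read by MTT assay, with a stated time of 96 h; on this read-out lower numbers stand for higher toxicity in this test and higher numbers for lower toxicity in this test. Compound 1 `Fc1ccc(-c2nc3cc(C(F)(F)F)ccc3[nH]2)cc1` gives 25000 nM in this assay. Compound 3 `O=C(CN1CCCCC1)Nc1ccc(-c2nc3ccccc3[nH]2)cc1` gives 31000 nM in this assay, and the two numbers sit within the usual scatter of each other, so compound 1 and compound 3 cannot be told apart on these figures. Compound 2 `Fc1cccc(F)c1-c1nc2cc(Cl)c(Cl)cc2[nH]1` returned no number in this assay but only a limit, > 100000 nM, namely (the limit of > 100000 nM in this assay, at which 1 of the 3 values shown sits). Of the two compounds with actual numbers, compound 1 is one, and it stands alongside compound 3 rather than apart from it.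

Compound 4 `O=[N+]([O-])c1ccc(-c2nc3cc(C(F)(F)F)ccc3[nH]2)cc1` has not yet been measured. It differs from compound 1 in a single place: nitro in place of fluoro on an aromatic carbon. Within the data shown here, no pair of measured compounds here differs by that same change, so nothing measured sets the size of the step. The step in this assay is therefore expected to be small, not clearly beyond the scatter, leaning if at all toward a lower number, and is estimated as a 1.3-fold lower number from compound 1 to compound 4 (0.10 log units; within the scatter). For compound 4 in this assay the estimated value is 20000 nM, expected to lie between 6000 nM and 60000 nM.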

Compound 4, half-maximal cytotoxic concentration: 18000 nM
The estimate for compound 4 lay 1.1-fold (0.05 log units) above the measured number; low and high end bracket the measured number.
By their numbers in this assay, from the lowest: compounds 4, 1 and 3 (each within the scatter of the next). At a limit, above all of these: compound 2.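

In this assay, nitro in place of fluoro on an aromatic carbon, para to a large group, gives a 1.4-fold lower number from compound 1 to compound 4 (0.14 log units; within the scatter) and so no change that can be told from the scatter. Among these compounds, this is the first reading of any single change at this place on the core of compound 1, and it shows that a single fluorine can give way to a group of 3 heavy atoms with 2 hydrogen-bond acceptors without the cytotoxicity figure moving measurably, so in this test the two groups cannot be told apart at this position. Nothing in the data shown accounts for this outcome, and with a step this small there is nothing that calls for explanation.

What the compounds shown leave open is whether this flat result extends to groups of another kind at the same carbon, such as an amine, a carboxylic acid or a longer chain. From the compounds shown here alone, it also remains open whether nitro in place of fluoro would give a similar step on a core carrying something other than trifluoromethyl, since this change is read only once.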